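A few compounds are considered here, and "the series" means these few. Any claim that something is new, unique, unknown or untested is made for them only; others in the source may bear on it.

In a toxicity assay on MDCK cells (Canis lupus familiaris) for cytotoxicity, read by CCK-8 assay, with a stated time of 48 h (on this read-out higher numbers stand for lower toxicity in this test and lower numbers for higher toxicity in this test), compound 1 `CC(C)(C)c1ccc(C(=O)NNc2c(Br)cccc2Br)cc1` gives > 100000 nM, which is a limit and not a number. This places compound 1 at the limit of > 100000 nM in this assay, at which 2 of the 3 values shown sit. Compound 3 `CCOc1ccc(C(=O)NNc2ccccc2Br)cc1` gives > 100000 nM, also a limit. Only compound 2 `CN(C)c1ccc(C(=O)NNc2c(Br)cc(Br)cc2Br)cc1`, which carries a dimethylamino group, gives an actual number, 20300 nM.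

Compound 4 `CCN(CC)c1ccc(C(=O)NNc2c(Br)cccc2Br)cc1` has diethylamino in place of tert-butyl on an aromatic carbon of compound 1: diethylamino in place of tert-butyl on an aromatic carbon. Going by the values given here, no measured pair isolates this change, so the expectation rests loosely on compound 2 at 20300 nM. A modest move toward lower numbers in this assay, meaning higher toxicity, is expected. The expected step is an at least 1.6-fold lower number from compound 1 to compound 4 (0.22 log units; that floor lies within the scatter). For compound 4 the estimate is 60000 nM, with an expected range of 20000 nM to 150000 nM.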

Compound 4, half-maximal cytotoxic concentration: 34000 nM
Compound 4: middle estimate off by 1.8-fold (0.25 log units), on the high side, within the range that was stated.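

In this assay, going by these compounds alone, putting diethylamino in place of tert-butyl on this aromatic carbon gives an at least 2.9-fold lower number from compound 1 to compound 4 (0.46 log units; beyond the scatter), the first change that can be read at a single place. It shows that this position, para to a large group, can affect toxicity in these cells, with the change going toward higher toxicity. The true size of the step remains unknown, as compound 1 stands at a limit and not at a number: the limit of > 100000 nM in this assay, at which 2 of the 4 values shown sit.

The compounds shown leave open how a primary amine or a longer carbon chain would read at this position. They also leave open whether diethylamino would produce a similar step on a core with a different pattern of bromine atoms.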